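The compounds below may be only part of what the source reports. "The series", "measured", "known", "first", "only" and "open" are said of these compounds alone.

In a functional assay for inhibition of sodium/hydrogen exchanger (Oryctolagus cuniculus) (a higher number here means a weaker inhibitor, a lower number a stronger inhibitor), compound 1 `Cc1cc(F)c(S(C)(=O)=O)cc1C(=O)N=C(N)N` gives 44 nM, compound 2 `CCCc1cc(C)c(C(=O)N=C(N)N)cc1S(C)(=O)=O` gives 5.7 nM and compound 3 `CCCCCc1cc(C)c(C(=O)N=C(N)N)cc1S(C)(=O)=O` gives 27 nM. Compound 3 thus holds the second highest of the three numbers: its gap to compound 1 lies within the scatter. The other gap lies beyond the scatter: a 4.7-fold higher number from compound 2 to compound 3 (0.68 log units; beyond the scatter).

Compound 4 `Cc1cc(-c2ccc(F)cc2)c(S(C)(=O)=O)cc1C(=O)N=C(N)N` carries 4-fluorophenyl in place of pentyl on an aromatic carbon. Among the measured compounds shown here, the steps that bear on this place are the two exchanges for fluoro and one chain extension: a 7.7-fold lower number from compound 1 to compound 2 (0.89 log units; beyond the scatter), a 1.6-fold lower number from compound 1 to compound 3 (0.21 log units; within the scatter) and a 4.7-fold higher number from compound 2 to compound 3 (0.68 log units; beyond the scatter). They show that groups at this aromatic carbon move the number by a modest amount in either direction, with no ring among them to guide the new one. Compound 4 is therefore expected to land near the measured compounds, with a modest step at most and its direction open, estimated as a 1.4-fold lower number from compound 3 to compound 4 (0.13 log units; within the scatter). For compound 4 the estimate in this assay is 20 nM, within a range from 5 nM to 80 nM.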

Compound 4, half-maximal inhibitory concentration: 36 nM
The estimate for compound 4 lay 1.8-fold (0.26 log units) below the measured number; the range from low to high includes it.
By their numbers in this assay, from the lowest: compound 2; then compounds 3, 4 and 1 (each within the scatter of the next).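

In this assay, this aromatic carbon, ortho to the methylsulfonyl group, proves to accept a six-membered aromatic ring: replacing pentyl with 4-fluorophenyl gives a 1.3-fold higher number from compound 3 to compound 4 (0.12 log units; within the scatter), and replacing fluoro with it gives a 1.2-fold lower number from compound 1 to compound 4 (0.09 log units; within the scatter). The ring, the pentyl chain and the fluoro group therefore cannot be told apart here, even though the ring brings the most heavy atoms of the three. Propyl alone stands apart, with a 6.3-fold higher number from compound 2 to compound 4 (0.80 log units; beyond the scatter), so compound 2 remains the strongest inhibitor of the four, and a ring at this carbon does not match it.

No measurement shown here explains why these groups behave as they do. As far as these compounds go, whether a butyl chain, an unsubstituted phenyl or a phenyl carrying an amine or a carboxylic acid would come closer to propyl remains open.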